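The source may hold more compounds than are shown below. What is called first, only, known or untested is meant among the compounds shown, and "the series" means these compounds.

Working notes on the series. Compound 1 `Nc1cccc(-c2cn3nc(-c4cccs4)sc3n2)c1` is the parent with a free aniline. In a functional assay on L1210 cells (Mus musculus) for inhibition, read by cell counting, with a stated time of 2 days (on this read-out lower numbers stand for stronger inhibition and higher numbers for weaker inhibition), compound 1 gives > 250000 nM, which is a limit of the assay and not a measured number; this is the point marked by the limit of > 250000 nM in this assay, at which 1 of the 2 values shown sits. Compound 2 `C=C(Br)C(=O)Nc1cccc(-c2cn3nc(-c4ccccc4)sc3n2)c1` differs from compound 1 in more than one place and is therefore not a single step; in this assay compound 2 gives 600 nM. Compound 3 `Nc1cccc(-c2cn3nc(Cc4ccccc4)sc3n2)c1` is the next single-point change from compound 1: benzyl in place of thiophen-2-yl on an aromatic carbon. For the measured compounds named here, no measured step between neighbours exists here, and compound 1 itself sits only at the limit, so the size of the change is expected to be none beyond the scatter, with compound 3 most probably also reported as a limit. For compound 3 the expected value in this assay is 250000 nM, in the range 60000 nM to 1000000 nM, which is the expected step of a number no higher from compound 1 to compound 3 (the limit leaves the size open).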

Compound 3, half-maximal inhibitory concentration: 7400 nM
The estimate for compound 3 lay 34-fold (1.53 log units) above the measured number; measured number below the stated range.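

In this assay compound 1 gives > 250000 nM, which is a limit of the assay and not a number: the limit of > 250000 nM in this assay, at which 1 of the 3 values shown sits.

With the free aniline kept, benzyl in place of thiophen-2-yl on an aromatic carbon gives an at least 33-fold lower number from compound 1 to compound 3 (1.52 log units; beyond the scatter). The earlier compounds shown here could not show this, since compound 2 differs from compound 1 in more than one place. This position, next to the ring nitrogen and next to the ring sulfur, therefore changes the read-out on its own, and in this assay compound 3 gives a measured 7400 nM.

The change swaps the ring and adds a linking carbon together, so the compounds shown leave open which of the two carries the step. From the compounds shown here alone, how a longer chain such as phenethyl, or an amine such as morpholine, would read at this position also stays open.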